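Extending a propyl chain with a terminal hydroxyl on an aroylindole

The source may hold more compounds than are shown below. What is called first, only, known or untested is meant among the compounds shown, and "the series" means these compounds.

Of the compounds shown here, three have been measured in a functional assay on KB cells (Homo sapiens) for inhibition; a higher number here means a weaker inhibitor, a lower number a stronger inhibitor. Compound 1 `COc1ccc2c(C)cc(N/N=C/c3ccccc3O)nc2c1` gives 2000 nM in this assay, and compound 2 `COc1ccc2ccccc2c1-c1cc(C(=O)N/N=C/c2cccs2)[nH]n1` gives 5700 nM. Compound 3 `CCCc1[nH]c2cc(OC)ccc2c1C(=O)c1cc(OC)c(OC)c(OC)c1` stands lowest of the three, with 11 nM in this assay; its gaps to compound 1 and to compound 2 both lie well beyond the usual scatter, so compound 3 is the strongest inhibitor among the measured set.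

Compound 4 `COc1ccc2c(C(=O)c3cc(OC)c(OC)c(OC)c3)c(CCCCCO)[nH]c2c1` has not yet been measured. It differs from compound 3 in one place: 2-hydroxyethyl in place of hydrogen on a saturated chain carbon, three bonds along the chain from an aromatic carbon. Going by the values given here, no measured pair in this set shows the effect of such a chain extension, so the expectation rests on the single measured value of compound 3 alone.

For compound 4 a modest step toward a higher number in this assay is expected, a 2.7-fold higher number from compound 3 to compound 4 (0.44 log units; beyond the scatter), though it could fall within the scatter. Compound 4 is therefore estimated at 30 nM, with a range from 8 nM to 150 nM.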

Compound 4, half-maximal inhibitory concentration: 57.3 nM
Compound 4: middle estimate off by 1.9-fold (0.28 log units), on the low side, within the range that was stated.
By their numbers in this assay, from the lowest: compound 3; then compound 4; then compound 1; then compound 2.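

In this assay, taking the propyl chain to 5-hydroxypentyl gives a 5.2-fold higher number from compound 3 to compound 4 (0.72 log units; beyond the scatter) and so weakens inhibition to a degree that exceeds the usual scatter. Going by these compounds alone, the step is the first reading at this position, and it shows that the chain can carry this longer hydroxylated group while compound 4 still gives 57.3 nM in this assay. Nothing available explains why the number rises.

The compounds shown leave open whether the step comes from the added chain length or from the terminal hydroxyl, a question that a plain pentyl chain would address. Going by these compounds, how a terminal amine or a carboxylic acid on the same chain would read in this assay also remains open.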